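Chain swap at the aryl ether: forecast for compound 3

The compounds below may be only part of what the source reports. "The series", "measured", "known", "first", "only" and "open" are said of these compounds alone.

Measured so far:
compound 1 `CCCCCOc1ccccc1C1CC(=O)c2ccccc2O1` gives 41.3%
compound 2 `CC(C)=CCOc1ccccc1C1CC(=O)c2ccccc2O1` gives 41.8%

In a functional assay on RAW264.7 cells (Mus musculus) for inhibition, read by immunoassay, with a stated time of 12 h, tested at 30 uM (a higher number here means more inhibition at the concentration tested (going by the name of the read-out), a lower number less inhibition), compound 2 holds the higher of the two numbers, yet the step of a number 0.5 percentage points higher from compound 1 to compound 2 (within the scatter) shows that compound 1 and compound 2 are indistinguishable within the scatter. Compound 3 `CCCCOc1ccccc1C1CC(=O)c2ccccc2O1` has not yet been measured in this assay. It differs from compound 2 by propyl in place of 2-methylprop-1-en-1-yl on a saturated chain carbon bound to an oxygen on an aromatic ring. Going by the values given here, the only measured step that bears on this change is the one from compound 1 to compound 2, which exchanged a butyl group for 2-methylprop-1-en-1-yl at the same place and moved the number by a number 0.5 percentage points higher from compound 1 to compound 2 (within the scatter). Since that exchange at this position left the read-out unchanged within the scatter, compound 3 is expected to show a step of a number 0.8 percentage points lower from compound 2 to compound 3 (within the scatter), none beyond the scatter. Compound 3 is therefore estimated at 41%, within the range 30% to 52%.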

Compound 3, a percentage reported as inhibition, at one concentration (the size of the read-out at that concentration, not a potency): 19.3%
Beside the measured number, compound 3's estimate is 21.7 percentage points above it; measured number outside the range, below it.
By their numbers in this assay, from the lowest: compound 3; then compounds 1 and 2 (each within the scatter of the next).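

In this assay, the chain on the saturated carbon bound to an oxygen on an aromatic ring proves able to move the read-out, which the earlier pair did not show: propyl in place of 2-methylprop-1-en-1-yl gives a number 22.5 percentage points lower from compound 2 to compound 3 (beyond the scatter). The loss of one terminal methyl alone, hydrogen in place of methyl four bonds along the chain from that oxygen, gives a number 22 percentage points lower from compound 1 to compound 3 (beyond the scatter), so compound 3 stands apart from both compound 1 and compound 2, and a small edit at the chain end is enough to matter here. Nothing available explains this drop.

The compounds shown leave open how a longer chain such as hexyl would read at this oxygen. They also leave open whether a benzyl group or a chain ending in an amine would hold the read-out of compound 1 and compound 2 or fall with compound 3.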